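The compounds below may be only part of what the source reports. "The series", "measured", "known", "first", "only" and "open" are said of these compounds alone.

Measured in an ADME assay on Vero cells (Chlorocebus sabaeus) for cytotoxicity, read by resazurin assay, with a stated time of 72 h; a higher number here means that more compound is needed for the effect, a lower number that less compound is needed:
- compound 1 `N#C[Se]CC1Cc2ccc(Oc3ccccc3)cc2O1`: > 20 uM
- compound 2 `FC(F)(F)SCCOc1ccc(Oc2ccccc2)cc1`: > 20 uM

Both entries are limits of the assay, not numbers. All the data so far come down to the limit of > 20 uM in this assay, at which 2 of the 2 values shown sit. Compound 2 stands at > 20 uM, which is a limit. Within the data shown here, no step between measured compounds is available, so the series gives no direct size for any structural change.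

Compound 3 `FC(F)(F)[Se]CCOc1ccc(Oc2ccccc2)cc1` keeps the core of compound 2 and alters one group on a saturated chain carbon, two bonds along the chain from an oxygen on an aromatic ring: a group of 5 heavy atoms (1 carbon, 3 fluorine, 1 selenium; no ring) in place of a group of 5 heavy atoms (1 carbon, 3 fluorine, 1 sulfur; no ring), on a saturated chain carbon, two bonds along the chain from an oxygen on an aromatic ring.

Among the measured compounds shown here, the only selenium-bearing compound measured is compound 1, and it gives > 20 uM, which is also a limit. That single compound offers no sign of a lower value for selenium, though it is thin support. The expectation in this assay is therefore no step beyond the scatter, and the assay may again report only a limit.

The expected step is a step that the limit leaves unreadable from compound 2 to compound 3.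

For compound 3 the estimated value is 22 uM, with an expected range of 9 uM to 50 uM.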

Compound 3, concentration for half-maximal effect: > 20 uM
Compound 3 ended at the assay's limit; the forecaster's own chance of this, stated with the estimate: 60%; the middle value lies beyond the limit too.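

In this assay no step can be read between compound 2 and compound 3, since both entries are limits and not numbers: the limit of > 20 uM in this assay, at which 3 of the 3 values shown sit.

The compounds shown leave open whether selenium in place of sulfur in this group shifts the concentration needed for the effect, and at what concentration any of the three compounds would reach it.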